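This account rests on a few compounds, and the source may have more. Where it says the series, first, only, none or still open, it means among the compounds named here.

Working notes on the series

Of the compounds shown here, three have been tested in a functional assay on MCF7 cells (Homo sapiens) for cytotoxicity, read by CCK-8 assay, with a stated time of 72 h (a higher number here means a weaker inhibitor, a lower number a stronger inhibitor), so far. Compound 1 `COc1ccccc1/C=c1/[nH]c(=O)/c(=C\c2ccccc2OC)[nH]c1=O` is reported in this assay as "not active" (no number reported), with no number given. Compound 2 `COc1ccccc1/C=c1\c(=O)[nH]/c(=C/c2cccc(Cl)c2Cl)c(=O)n1C` gives 200 nM in this assay. Compound 3 `C=CCn1c(=O)/c(=C\c2cccc(F)c2)[nH]c(=O)/c1=C\c1ccccc1OC` gives 13700 nM in this assay. Among the two compounds with a number, compound 3 stands highest, and its gap to compound 2 is well beyond the usual scatter of the assay; no single structural step connects the two, as they differ in more than one place.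

The next compound, compound 4 `C=CCn1c(=O)/c(=C\c2ccc(F)c(Br)c2)[nH]c(=O)/c1=C\c1ccccc1OC`, differs from compound 3 in one place: 3-bromo-4-fluorophenyl in place of 3-fluorophenyl on a double-bonded chain carbon bound to an aromatic carbon. Nothing measured in the series isolates this change, so the direction of the step in this assay is open. The change adds a bromine to the ring while keeping the fluorine, and a modest downward step is expected rather than a large one, since compound 3 13700 nM is the only direct point of reference. Compound 4 is therefore estimated at 7000 nM, with a range from 1500 nM to 30000 nM. The expected step from compound 3 to compound 4 is a 2.0-fold lower number from compound 3 to compound 4 (0.29 log units; within the scatter), which may well lie within the scatter.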

Compound 4, half-maximal inhibitory concentration: "not active" (no number reported)
Compound 4 has no reported number here; no gap can be computed for the estimate.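

With no number for compound 4 in this assay, no step can be read between compound 3 and compound 4. No available evidence bears on this result. The compounds shown leave open how 3-bromo-4-fluorophenyl in place of 3-fluorophenyl changes the number in this assay, and which single changes separate compound 2 from compound 3.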